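The compounds below may be only part of what the source reports. "The series", "measured", "known", "first", "only" and "open" are said of these compounds alone.

In a functional assay on the whole organism with Mus musculus as the target (on this read-out higher numbers stand for an effect only at larger amounts of compound and lower numbers for an effect already at smaller amounts), compound 1 (`NC(=O)/C=C/c1cccc(C(F)(F)F)c1`) gives 37.5 mg/kg as its measured dose. Compound 2 (`O=C1CCC(O)(c2cccc(C(F)(F)F)c2)N1`) yields no number in this read-out, and its entry of > 200 mg/kg is a limit of the assay. Compound 3 (`CN1C(=O)CCC1(O)c1cccc(C(F)(F)F)c1`) differs from compound 2 in a single place, methyl in place of hydrogen on an amide-type nitrogen in a ring, counted as methyl in place of hydrogen on an amide-type nitrogen in a ring in the structures. Going by the values given here, no measured pair of compounds shows what such a change does in this assay, so any expectation here is loose. A moderate shift towards smaller doses is expected, although compound 3 may well also end at the limit of the assay. The estimate means an at least 1.6-fold lower number from compound 2 to compound 3 (0.22 log units; that floor lies within the scatter) as the expected step. For compound 3 the expected dose is 120 mg/kg on this estimate, with a range from 45 mg/kg to 320 mg/kg expected.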

Compound 3, dose for half-maximal effect: 93.8 mg/kg
Compound 3: the middle estimate sits 1.3-fold (0.11 log units) above what was measured, and the stated range covers the measured number.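

In this assay, going by these compounds alone, replacing the amide hydrogen with methyl gives an at least 2.1-fold lower number from compound 2 to compound 3 (0.32 log units; beyond the scatter), the first readable step at this position. The nitrogen of the five-membered ring is therefore a place where a single added carbon can turn a compound without a measured dose into one with a number. The true size of the step remains unknown, and the printed size is only a floor: the limit of > 200 mg/kg in this assay, at which 1 of the 3 values shown sits.

The compounds shown leave open whether an ethyl group or a longer chain on this nitrogen would lower the number further or give the gain back. They also leave open whether the same methyl would have a similar effect if an amine or a methoxy group replaced the hydroxy group on the ring atom that bears it.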